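From a Methylphenyl to a Chlorophenyl: Expected Cytotoxicity

The compounds below may be only part of what the source reports. "The series", "measured", "known", "first", "only" and "open" are said of these compounds alone.

Of the compounds shown here, three sharing one core have been tested in an ADME assay on Vero cells (Chlorocebus sabaeus) for cytotoxicity, read by neutral red uptake, tested at 197 ug/mL; a lower number here means a stronger effect, a higher number a weaker effect of the compound at the concentration tested. Compound 1 `O=C1CSC(c2cccc(O)c2)N1CCN1CCCCC1` carries a 3-hydroxyphenyl group on a saturated ring carbon, and in this assay compound 1 gives 100%. Compound 2 `O=C1CSC(c2ccccc2[N+](=O)[O-])N1CCN1CCCCC1` carries a 2-nitrophenyl group instead, and in this assay compound 2 gives 100%. Compound 3 `Cc1ccc(C2SCC(=O)N2CCN2CCCCC2)cc1` carries a 4-methylphenyl group; in this assay compound 3 gives 85%, the lowest of the three numbers. Going by the values given here, the only single-place step measured so far is a number 15 percentage points lower from compound 1 to compound 3 (beyond the scatter), a modest drop. Compounds 1 and 2 return the same full value, so the two aryl groups they carry do not separate them.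

Compound 4 `O=C1CSC(c2ccccc2Cl)N1CCN1CCCCC1` is the next compound: 2-chlorophenyl in place of 4-methylphenyl on a saturated ring carbon. Among the compounds with values here, the one measured step that bears on this change is the step from compound 1 to compound 3, which also exchanged the aryl group on the same saturated ring carbon and was modest. Exchanging one aryl group for another is therefore expected to move the number only a little. The expected step of a number 7 percentage points higher from compound 3 to compound 4 (within the scatter) is small, likely slightly upward toward the level seen for compounds 1 and 2, but possibly none beyond the scatter. Compound 4 is estimated at 92%, within a range from 78% to 100%.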

Compound 4, a percentage reported as activity, at one concentration (the size of the read-out at that concentration, not a potency): 71%
Compound 4: the middle estimate sits 21 percentage points above what was measured; measured number below the stated range.
By their numbers in this assay, from the lowest: compound 4; then compound 3; then compounds 1 and 2 (each within the scatter of the next).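

In this assay, going by these compounds alone, the choice of aryl group on this saturated ring carbon proves able to move the number further than the earlier compounds showed: 2-chlorophenyl in place of 4-methylphenyl gives a number 14 percentage points lower from compound 3 to compound 4 (beyond the scatter), and 2-chlorophenyl in place of 3-hydroxyphenyl gives a number 29 percentage points lower from compound 1 to compound 4 (beyond the scatter). The closest comparison changes only the group on an aromatic carbon, and chloro in place of nitro gives a number 29 percentage points lower from compound 2 to compound 4 (beyond the scatter), so 2-nitrophenyl and 2-chlorophenyl do not behave alike, and the name of the group matters here, not just the number in that name. No measurement among those available explains why these aryl groups give different numbers.

As far as these compounds go, what stays open is whether the lower number follows the chloro group itself or its place on the aromatic ring, a question that a 4-chlorophenyl and a 2-methylphenyl compound on the same core could help to settle. From the compounds shown here alone, it is also open how far the number would move with a bromo, a methoxy or an amino group on the aromatic carbon in place of chloro.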